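Methoxy addition on the anilide ring and macrophage cytotoxicity

The source may hold more compounds than are shown below. What is called first, only, known or untested is meant among the compounds shown, and "the series" means these compounds.

Compound 1 `O=C(Nc1cccc(C(F)(F)F)c1)c1cc(Cl)ccc1O`, compound 2 `O=C(Nc1ccccc1C(F)(F)F)c1cc(Cl)ccc1O` and compound 3 `COc1ccc(C(F)(F)F)c(NC(=O)c2cc(Cl)ccc2O)c1` share a core and were all tested in an ADME assay on cells (Macrophage, Mus musculus) for cytotoxicity, read by resazurin assay, with a stated time of 3 days; on this read-out higher numbers stand for weaker inhibition and lower numbers for stronger inhibition. Compound 1 gives 5900 nM. Compound 2 gives 19000 nM, and compound 3 gives 4800 nM. The numbers of compound 1 and compound 3 lie within the scatter of each other, while compound 2 stands apart from compound 1 beyond the scatter. Compound 1 and compound 2 have the same atoms joined differently; the difference between the two cores is not broken down here.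

Between compound 2 and compound 3 one change is made, (methoxy in place of hydrogen on an aromatic carbon), and this gives a 4.0-fold lower number from compound 2 to compound 3 (0.60 log units; beyond the scatter).

Compound 4 `COc1cc(NC(=O)c2cc(Cl)ccc2O)cc(C(F)(F)F)c1` arises from compound 1 by the same kind of change, (methoxy in place of hydrogen on an aromatic carbon); here the methoxy sits meta to the trifluoromethyl group rather than para to it, so the two changes are alike in kind but not the same. Because the earlier change gave a 4.0-fold lower number from compound 2 to compound 3 (0.60 log units; beyond the scatter), a smaller step of about a 2.0-fold lower number from compound 1 to compound 4 (0.29 log units; within the scatter) is expected from compound 1 to compound 4. Compound 4 is therefore estimated at 3000 nM, most likely between 1200 nM and 8000 nM.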

Compound 4, half-maximal inhibitory concentration: 18000 nM
Compound 4: the middle estimate sits 6.0-fold (0.78 log units) below what was measured, and the stated range ends below it.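

In this assay, methoxy in place of hydrogen now gives a 3.1-fold higher number from compound 1 to compound 4 (0.48 log units; beyond the scatter), which is the opposite direction to the earlier step and means weaker inhibition rather than stronger. The same kind of change therefore did not carry over from one core to the other, as the two steps set side by side show: the same change on two cores in this assay, a 4.0-fold lower number (0.60 log units; beyond the scatter) from compound 2 to compound 3 and a 3.1-fold higher number (0.48 log units; beyond the scatter) from compound 1 to compound 4, 12-fold (1.08 log units) apart, beyond the scatter of two such steps. This does not show why the steps part ways: the methoxy stands in a different place relative to the trifluoromethyl group in the two pairs and the cores differ as well, and two steps cannot tell those two differences apart.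

The compounds shown leave open how methoxy would behave in the place it holds in compound 4 if it were put on the core of compound 2, a comparison that would separate position from core. They also leave open whether another group in the same place, such as an amine or a carboxylic acid, would raise or lower the number.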